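Amide series: dichlorophenyl to dimethoxyphenyl step

The source may report more compounds than this note shows. Statements on the series, on what has been measured and on what is new or still open speak of the compounds shown alone.

Measured in a functional assay on HL-60 cells (Homo sapiens) for inhibition, read by MTT assay, with a stated time of 72 h; on this read-out higher numbers stand for weaker inhibition and lower numbers for stronger inhibition:
- compound 1, `CC(=O)c1ccc(N2CCN(C(=O)c3oc(C)nc3-c3ccccc3)CC2)cc1`: "not active" (no number reported)
- compound 2, `Cc1nc(-c2ccccc2)c(C(=O)N2CCN(c3cc(Cl)cc(Cl)c3)CC2)o1`: 41.8 nM

Among the compounds with values here, compound 2 is the only compound of the series with a number in this assay; compound 1 is reported without activity and without a number, so nothing about the size of the gap between the two can be drawn from it. Within the data shown here, the single value of compound 2 is therefore the whole reference for what follows.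

Compound 3, `COc1cc(OC)cc(N2CCN(C(=O)c3oc(C)nc3-c3ccccc3)CC2)c1`, is the next compound to be measured in this assay. Its difference from compound 2 is 3,5-dimethoxyphenyl in place of 3,5-dichlorophenyl on an amine nitrogen in a ring.

Among the measured compounds shown here, no step between measured compounds exists, so the expected size of the change must rest on the one value of compound 2 in this assay alone. The expectation is a moderate weakening, beyond the usual scatter but not large, and the step of a 4.3-fold higher number from compound 2 to compound 3 (0.63 log units; beyond the scatter) is the estimated change. For compound 3 the expected value in this assay is 180 nM, with a range from 50 nM to 900 nM; a result reported only as a limit is also possible.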

Compound 3, half-maximal inhibitory concentration: 19.2 nM
For compound 3 the middle estimate is 9.4-fold (0.97 log units) above the measured one; measured number outside the range, below it.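

In this assay, the 3,5-dichlorophenyl on the amine nitrogen in the ring proves replaceable without loss of inhibition: 3,5-dimethoxyphenyl in its place gives a 2.2-fold lower number from compound 2 to compound 3 (0.34 log units; beyond the scatter). Within the data shown here, this is the first comparison between two numbers, and it shows that this position accepts a group of 10 heavy atoms in place of 8, with 2 hydrogen-bond acceptors in place of 0, and that the change moves toward stronger inhibition. Nothing measured here accounts for the gain, so the step stands as an observation only.

Still open, on these data alone, is whether the gain needs both methoxy groups or only one, and how much of the activity depends on the substitution pattern itself: compound 1, with its acetyl-bearing phenyl at the same place, is reported as "not active" (no number reported), and that entry gives no size for the gap. Also open, as far as these compounds go, is how an amine, a carboxylic acid or a longer chain such as ethoxy would read at this place in this assay.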